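Swapping cyano for fluoro on compound 3

The compounds below may be only part of what the source reports. "The series", "measured", "known", "first", "only" and "open" are said of these compounds alone.

Values so far in an ADME assay on microsomes from liver (Homo sapiens) for metabolic stability, read by LC-MS, with a stated time of 1 h (on this read-out lower numbers stand for a less stable compound and higher numbers for a more stable compound), are these
compound 1 `CCOc1ccccc1-c1ccc(CO[C@@H]2COc3nc([N+](=O)[O-])cn3C2)cc1` gives 50%
compound 2 `O=[N+]([O-])c1cn2c(n1)OC[C@@H](OCc1ccc(-c3ccc(CNc4ccccc4)cc3)cc1)C2` gives 12%
compound 3 `N#Cc1ccc(-c2ccc(CO[C@@H]3COc4nc([N+](=O)[O-])cn4C3)cc2)cc1` gives 95%

Compound 3 stands highest of the three at 95% in this set, and both gaps to it lie beyond the scatter. The next case is compound 4 `O=[N+]([O-])c1cn2c(n1)OC[C@@H](OCc1ccc(-c3ccc(F)cc3)cc1)C2` which has not yet been measured. Its change from compound 3 (fluoro in place of cyano on an aromatic carbon) is fluoro in place of cyano on an aromatic carbon, para to a large group.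

Going by the values given here, two measured steps bear on this change. One is a number 45 percentage points higher from compound 1 to compound 3 (beyond the scatter) and the other is a number 83 percentage points higher from compound 2 to compound 3 (beyond the scatter) so both are large. Neither exchanges cyano for fluoro, so they guide the expectation only loosely. Compound 4 carries neither the 2-ethoxyphenyl of compound 1 nor the anilinomethyl of compound 2, which argues against a fall of that size. With compound 3 at 95% there is little room upward, so a modest fall is more likely than a rise. The expected step is a number 15 percentage points lower from compound 3 to compound 4 (beyond the scatter) and it should be smaller than either measured step. Compound 4 is estimated at 80% in this assay with an expected range from 58% to 95% as its bounds.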

Compound 4, percent of the compound remaining: 75%
Compound 4: middle estimate off by 5 percentage points, on the high side; measured number inside the range.
By their numbers in this assay, from the lowest: compound 2; then compound 1; then compound 4; then compound 3.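

In this assay, going by these compounds alone, compound 4 shows that cyano and fluoro are not interchangeable at this place, para to a large group on the six-membered aromatic ring, since this single exchange gives a measurable change (a number 20 percentage points lower from compound 3 to compound 4 (beyond the scatter)) even though both groups are far simpler than those in the earlier compounds. Fluoro nonetheless retains much of the read-out, standing well clear of anilinomethyl (a number 63 percentage points higher from compound 2 to compound 4 (beyond the scatter)), and 4-fluorophenyl likewise stands clear of 2-ethoxyphenyl (a number 25 percentage points higher from compound 1 to compound 4 (beyond the scatter)), so the high number of compound 3 does not depend on cyano alone, although cyano gives the highest number among these compounds. Nothing measured here accounts for the difference between any of these groups.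

On these data alone, whether a chloro, methoxy, primary amine or carboxylic acid group at this place would give a number nearer that of compound 3 or that of compound 4 in this assay remains open. As far as these compounds go, it is also open whether the exchange of cyano for fluoro would give a step of similar size with a change elsewhere on the shared core.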